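Chain oxygen alkyl variation in a trimethoxybenzyl series

The source may hold more compounds than are shown below. What is called first, only, known or untested is meant among the compounds shown, and "the series" means these compounds.

Measured compounds:
Compound 1 `COc1cc(Cc2nc3c(N)ncnc3n2CCCC(C)C)cc(OC)c1OC`: 69200 nM
Compound 2 `COc1cc(Cc2nc3c(N)ncnc3n2CC(C)C)cc(OC)c1OC`: 97700 nM
Compound 3 `COCCn1c(Cc2cc(OC)c(OC)c(OC)c2)nc2c(N)ncnc21`: 64600 nM

All three compounds were tested in a functional assay on MCF7 cells (Homo sapiens) for antiproliferative activity; on this read-out lower numbers stand for stronger inhibition and higher numbers for weaker inhibition. Compound 1 gives 69200 nM in this assay, compound 2 gives 97700 nM and compound 3 gives 64600 nM. Compound 3 stands apart from neither neighbour: its number sits a 1.1-fold lower number from compound 1 to compound 3 (0.03 log units; within the scatter) and a 1.5-fold lower number from compound 2 to compound 3 (0.18 log units; within the scatter), so the three values lie together within the scatter.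

Compound 4 `COc1cc(Cc2nc3c(N)ncnc3n2CCOC(C)C)cc(OC)c1OC` has not yet been measured. It differs from compound 3 in one place: isopropyl in place of methyl on an oxygen on a saturated carbon.

Among the measured compounds shown here, three measured steps concern the same chain on the aromatic nitrogen. Exchanging isopentyl for isopropyl gave a 1.4-fold higher number from compound 1 to compound 2 (0.15 log units; within the scatter); exchanging isobutyl for methoxy gave a 1.1-fold lower number from compound 1 to compound 3 (0.03 log units; within the scatter); exchanging isopropyl for methoxymethyl gave a 1.5-fold lower number from compound 2 to compound 3 (0.18 log units; within the scatter). For the measured compounds named here, none of these changes to the chain moved the number beyond the scatter, although no measured step alters the alkyl group on the oxygen itself. Compound 4 is therefore expected to show a 1.0-fold higher number from compound 3 to compound 4 (0.00 log units; within the scatter), no step beyond the scatter.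

The estimate for compound 4 in this assay is 65000 nM, with a range from 30000 nM to 140000 nM.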

Compound 4, half-maximal inhibitory concentration: 38900 nM
Compound 4: middle estimate off by 1.7-fold (0.22 log units), on the high side; the measured number falls inside the stated range.
By their numbers in this assay, from the lowest: compounds 4, 3, 1 and 2 (each within the scatter of the next, the first and the last beyond it).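

Among the compounds shown here, on the oxygen of the 2-methoxyethyl chain, isopropyl in place of methyl gives a 1.7-fold lower number from compound 3 to compound 4 (0.22 log units; within the scatter) in this assay, so this first change at the oxygen itself, the one alkyl swap there, stays inside the usual variation of the measurement. Compound 4 also stays within that variation of the all-carbon chain of compound 1, with a 1.8-fold lower number from compound 1 to compound 4 (0.25 log units; within the scatter), but it separates from compound 2, with a 2.5-fold lower number from compound 2 to compound 4 (0.40 log units; beyond the scatter), a modest step and the only one beyond the scatter in this set, whereas compound 3 with its 2-methoxyethyl chain did not separate from compound 2. No measurement at hand gives a reason for this small separation.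

With only methyl and isopropyl on this oxygen, the compounds shown leave open whether an ethyl group, a cyclopropyl ring or a longer chain there would move the number clearly away from that of compound 3. They also leave open whether an amine or a carboxylic acid on the same chain would do so, since every chain shown carries only carbon and ether oxygen.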